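From compound 3 to compound 4: exchanging the aryl group

The source may hold more compounds than are shown below. What is called first, only, known or untested is meant among the compounds shown, and "the series" means these compounds.

In a functional assay on M21 cells (Homo sapiens) for antiproliferative activity, read by sulforhodamine B assay, with a stated time of 48 h (on this read-out lower numbers stand for stronger inhibition and higher numbers for weaker inhibition), compound 3 `CCCN1CCN(c2ccc(S(=O)(=O)Oc3ccc(C)cc3C)cc2)C1=O` gives 9700 nM, the highest number in the set, against compound 1 `Cc1ccc(OS(=O)(=O)c2ccc(N3CCN(C)C3=O)cc2)c(C)c1` at 1800 nM and compound 2 `COc1cccc(OS(=O)(=O)c2ccc(N3CCN(C)C3=O)cc2)c1` at 1600 nM. Compound 4 `CCCN1CCN(c2ccc(S(=O)(=O)Oc3cccc(OC)c3)cc2)C1=O` carries 3-methoxyphenyl in place of 2,4-dimethylphenyl on an oxygen. The same exchange has been measured once, as a 1.1-fold lower number from compound 1 to compound 2 (0.05 log units; within the scatter). The other measured step, a 5.4-fold higher number from compound 1 to compound 3 (0.73 log units; beyond the scatter), concerns a different place and sets only the starting level. From the compounds shown here alone, whether the exchange behaves alike in compound 3 is untested. The step expected is a 1.1-fold lower number from compound 3 to compound 4 (0.05 log units; within the scatter), so no change beyond the scatter is anticipated. For compound 4 the estimated value is 8600 nM, with an expected range of 4500 nM to 16000 nM.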

Compound 4, half-maximal inhibitory concentration: 10000 nM
Estimate against measurement, compound 4: 1.2-fold (0.07 log units) below; low and high end bracket the measured number.
By their numbers in this assay, from the lowest: compounds 2 and 1 (each within the scatter of the next); then compounds 3 and 4 (each within the scatter of the next).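

In this assay, 3-methoxyphenyl in place of 2,4-dimethylphenyl on an oxygen again gives no change beyond the scatter (a 1.0-fold higher number from compound 3 to compound 4 (0.01 log units; within the scatter)), now on the propyl-bearing core, and the two readings agree: the same change on two cores in this assay, a 1.1-fold lower number (0.05 log units; within the scatter) from compound 1 to compound 2 and a 1.0-fold higher number (0.01 log units; within the scatter) from compound 3 to compound 4, 1.2-fold (0.06 log units) apart, within the scatter of two such steps.
The ethyl in place of hydrogen step also carries over to the 3-methoxyphenyl compounds (a 6.3-fold higher number from compound 2 to compound 4 (0.80 log units; beyond the scatter)), so across these four compounds the two places read as additive: the same change on two cores in this assay, a 5.4-fold higher number (0.73 log units; beyond the scatter) from compound 1 to compound 3 and a 6.3-fold higher number (0.80 log units; beyond the scatter) from compound 2 to compound 4, 1.2-fold (0.06 log units) apart, within the scatter of two such steps.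
Open, from the compounds shown here alone, are a butyl or longer chain at the chain position and aryl groups carrying an amine or a carboxylic acid on the oxygen.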